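Solubility notes: removing the oxan-4-yl substituent

This account rests on a few compounds, and the source may have more. Where it says the series, first, only, none or still open, it means among the compounds named here.

Compound 1 `Cc1nc(C)n(CC(=O)N2CCN(c3sc(C(F)(F)F)nc3-c3nc4ccc(C5CCOCC5)cc4[nH]3)C[C@H]2C)n1` stands at a limit in a physicochemical assay for solubility, in simulated intestinal fluid; on this read-out lower numbers stand for lower solubility and higher numbers for higher solubility: compound 1 gives > 1000 ug/mL, which is a limit of the assay and not a number. Compound 2 `Cc1nc(C)n(CC(=O)N2CCN(c3sc(C(F)(F)F)nc3-c3nc4c(F)cccc4[nH]3)C[C@H]2C)n1` gives 750 ug/mL in this assay. Compound 3 `Cc1nc(C)n(CC(=O)N2CCN(c3sc(C(F)(F)F)nc3-c3nc4ccccc4[nH]3)C[C@H]2C)n1` differs from compound 1 by hydrogen in place of oxan-4-yl on an aromatic carbon. For the measured compounds named here, no measured step covers this change, and the only fixed point is the limit of > 1000 ug/mL in this assay, at which 1 of the 2 values shown sits, so the expectation rests on the two values alone. From compound 1 to compound 3 a modest downward step is expected, an at least 1.4-fold lower number from compound 1 to compound 3 (0.15 log units; that floor lies within the scatter), perhaps not beyond the scatter. Compound 3 is expected to give 700 ug/mL, within 300 ug/mL to 1500 ug/mL.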

Compound 3, solubility: > 850 ug/mL
Compound 3 gave a limit, no number; the forecaster's own chance of this, stated with the estimate: 30%; middle value at least 1.2-fold (0.08 log units) away from the limit.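

In this assay compound 3 gives > 850 ug/mL, which is a limit of the assay and not a number. Thus, with hydrogen in place of oxan-4-yl on the aromatic carbon, the read-out still gives no number, and the step between compound 1 and compound 3 cannot be read. For the compounds shown here, the one readable step is an at least 1.1-fold higher number from compound 2 to compound 3 (0.05 log units; that floor lies within the scatter), for hydrogen in place of fluoro on an aromatic carbon.

As far as these compounds go, the true distance between compound 1 and compound 3 stays open. Also open, from the compounds shown here alone, is whether an amine or a carboxylic acid on that aromatic carbon would give a number in this assay.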